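Chalcone-triazole amides: bromobenzyl in place of decyl

A few compounds are considered here, and "the series" means these few. Any claim that something is new, unique, unknown or untested is made for them only; others in the source may bear on it.

Measured so far:
compound 1, `CC(C)(C)OC(=O)N1CCN(CC(=O)Nc2ccc(C(=O)/C=C/c3cn(Cc4ccc(Br)cc4)nn3)cc2)CC1`, 18900 nM
compound 2, `CCCCCCCCCCn1cc(/C=C/C(=O)c2ccc(NC(=O)CN3CCN(c4ccccc4OC)CC3)cc2)nn1`, 50800 nM

In a functional assay on HeLa cells (Homo sapiens) for inhibition, read by MTT assay (a higher number here means a weaker inhibitor, a lower number a stronger inhibitor), compound 2 gives the higher of the two numbers; compound 1 sits at a lower value, and the gap between the two lies beyond the usual scatter. Within the data shown here, the two compounds differ in more than one place, so no single step between them is counted.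

Compound 3 is `COc1ccccc1N1CCN(CC(=O)Nc2ccc(C(=O)/C=C/c3cn(Cc4ccc(Br)cc4)nn3)cc2)CC1`. Relative to compound 2 the change is 4-bromophenyl in place of nonyl on a saturated chain carbon bound to an aromatic nitrogen. Among the measured compounds shown here, the rest of compound 3 matches compound 2; the 4-bromobenzyl group on the triazole nitrogen is the one found in compound 1.

For the measured compounds named here, no measured step covers this change. Because compound 1, which carries the same 4-bromobenzyl group, gives 18900 nM, a downward step in this assay of modest size is expected for compound 3. The estimate for compound 3 in this assay is 22000 nM, expected between 8000 nM and 60000 nM, giving an expected step of a 2.3-fold lower number from compound 2 to compound 3 (0.36 log units; beyond the scatter).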

Compound 3, half-maximal inhibitory concentration: 26400 nM
Compound 3: middle estimate off by 1.2-fold (0.08 log units), on the low side; the measured number falls inside the stated range.
By their numbers in this assay, from the lowest: compounds 1, 3 and 2 (each within the scatter of the next, the first and the last beyond it).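

In this assay, 4-bromophenyl in place of nonyl on a saturated chain carbon bound to an aromatic nitrogen gives a 1.9-fold lower number from compound 2 to compound 3 (0.28 log units; within the scatter), so this assay does not separate the decyl and 4-bromobenzyl groups in this pair. With the 4-bromobenzyl group held fixed, 2-methoxyphenyl in place of tert-butoxycarbonyl on an amine nitrogen in a ring gives a 1.4-fold higher number from compound 1 to compound 3 (0.15 log units; within the scatter), so the two groups on that ring nitrogen are not separated either. No measurement bears on why these steps are this size.

Open, going by these compounds, is whether a butyl chain or a 4-aminobenzyl group at the first position would give a step beyond the scatter. Equally open, on these data alone, is whether an acetyl group in place of 2-methoxyphenyl on the amine nitrogen in a ring would do so.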